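The compounds below may be only part of what the source reports. "The series", "measured", "known", "first", "only" and "open" are said of these compounds alone.

Of the compounds shown here, two sharing one core have been measured in a functional assay on HeLa cells (Homo sapiens) for inhibition, read by CCK-8 assay, with a stated time of 48 h; on this read-out lower numbers stand for stronger inhibition and higher numbers for weaker inhibition. Compound 1 (`COc1cc(-c2ccnc3cc(-c4cn(CO)c5ccccc45)nn23)cc(OC)c1OC`) gives 103 nM, and compound 2 (`COc1cc(-c2ccnc3cc(-c4ccc(Cl)cc4)nn23)cc(OC)c1OC`) gives 1490 nM. Compound 2 therefore holds the higher of the two numbers and is the weaker inhibitor, with a gap to compound 1 that lies beyond the scatter. These two compounds differ in more than one place, so no measured single change is available as a guide.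

Compound 3 (`COc1cc(-c2ccnc3cc(-c4cccc(C#N)c4)nn23)cc(OC)c1OC`) is next in this assay. It has 3-cyanophenyl in place of 4-chlorophenyl on an aromatic carbon. Compound 2, at 1490 nM, is the closer reference, as it also carries a substituted phenyl group at this place. The data contain no comparison of these two phenyl groups, so neither direction is strongly favoured. The expected change, a 1.4-fold lower number from compound 2 to compound 3 (0.13 log units; within the scatter), is small, with a slight lowering of the number and nothing beyond the scatter. Compound 3 is estimated at 1100 nM, with an expected range from 350 nM to 3800 nM.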

Compound 3, half-maximal inhibitory concentration: > 10000 nM
Compound 3 ended at the assay's limit; the forecaster's own chance of this, stated with the estimate: 5%; middle value at least 9.0-fold (0.95 log units) from the limit.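

In this assay, the replacement of 4-chlorophenyl by 3-cyanophenyl gives an at least 6.7-fold higher number from compound 2 to compound 3 (0.82 log units; beyond the scatter), the first change in a single place among these compounds, since compound 1 and compound 2 differ in more than one place. It shows that this aromatic carbon of the five-membered aromatic ring, next to the ring nitrogen, does not treat all substituted phenyl groups alike: the choice of phenyl group here can move the number well beyond the scatter. The entry for compound 3 is a limit of the assay and not a number: the limit of > 10000 nM in this assay, at which 1 of the 3 values shown sits.

The step changes two things together, the group on the phenyl ring and its place on that ring, so the compounds shown do not tell whether the loss of the chlorine, the arrival of the nitrile or the new place of the group carries the effect. Also open, as far as these compounds go, is how this position would respond to a plain phenyl ring, or to a phenyl ring bearing an amine or a methoxy group.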